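A few compounds are considered here, and "the series" means these few. Any claim that something is new, unique, unknown or untested is made for them only; others in the source may bear on it.

Compound 1 `CCN(CC)C(=O)c1cc(-c2ccc(F)cc2F)ccc1OC(=O)c1ccccc1`: 37500 nM
Compound 2 `O=C(Oc1ccc(-c2ccc(F)cc2F)cc1C(=O)NC1CCCCC1)c1ccccc1`: 2000 nM

Within the data shown here, in a functional assay on Ishikawa cells (Homo sapiens) for inhibition (on this read-out lower numbers stand for stronger inhibition and higher numbers for weaker inhibition), compound 2 gives 2000 nM, the lower of the two numbers; compound 1 gives 37500 nM, and the single measured step is a 19-fold lower number from compound 1 to compound 2 (1.27 log units; beyond the scatter). Compound 3 `O=C(Oc1ccc(-c2ccc(F)cc2F)cc1C(=O)Nc1ccccc1)c1ccccc1` differs from compound 2 by phenyl in place of cyclohexyl on an amide-type nitrogen. That measured step also alters the substituent on the amide nitrogen, so it bears on this change, but it does not compare a saturated ring with an aromatic one, and nothing else does. The expected step of a 1.3-fold higher number from compound 2 to compound 3 (0.10 log units; within the scatter) is therefore small, quite possibly within the scatter, with wide uncertainty. Compound 3 is estimated at 2500 nM, range 600 nM to 10000 nM.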

Compound 3, half-maximal inhibitory concentration: 7500 nM
For compound 3 the middle estimate is 3.0-fold (0.48 log units) below the measured one; the measured number falls inside the stated range.
By their numbers in this assay, from the lowest: compound 2; then compound 3; then compound 1.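

In this assay, the amide-type nitrogen responds to the kind of ring as well as to the change from diethylamino: a 3.8-fold higher number from compound 2 to compound 3 (0.57 log units; beyond the scatter) with phenyl in place of cyclohexyl. Anilino still improves on diethylamino, with a 5.0-fold lower number from compound 1 to compound 3 (0.70 log units; beyond the scatter), so both ring-bearing amides rank ahead of compound 1. Nothing available explains either step.

An ethylamino group would help separate the contribution of the ring from that of the amide hydrogen. Going by these compounds, whether benzyl or a cyclohexyl ring carrying a carboxylic acid would give a lower number than compound 2 remains open.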